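The source may hold more compounds than are shown below. What is called first, only, known or untested is meant among the compounds shown, and "the series" means these compounds.

Measured so far in a functional assay on A549 cells (Homo sapiens) for cytotoxicity, read by MTT assay, with a stated time of 72 h; on this read-out higher numbers stand for weaker inhibition and lower numbers for stronger inhibition:
- compound 1 `COc1ncc(-c2ccc3nc(NC(=O)NC4CC4)nn3c2)cc1NS(=O)(=O)c1ccc(F)cc1`: 210 nM
- compound 2 `COc1ncc(-c2ccc3nc(NC(=O)NCCN4CCCCC4)nn3c2)cc1NS(=O)(=O)c1ccc(F)cc1`: 610 nM
- compound 3 `COc1ncc(-c2ccc3nc(NC(=O)NCC(=O)N4CCCC4)nn3c2)cc1NS(=O)(=O)c1ccc(F)cc1`: 2190 nM

Compound 3, at 2190 nM, has the highest number of the three, and its steps to both others lie beyond the scatter. The next compound to be read is compound 4 `CCCNC(=O)Nc1nc2ccc(-c3cnc(OC)c(NS(=O)(=O)c4ccc(F)cc4)c3)cn2n1`. The structural change is ethyl in place of (pyrrolidin-1-yl)carbonyl on a saturated chain carbon bound to an amide-type nitrogen. In other words, ((pyrrolidin-1-yl)carbonyl)methyl becomes propyl.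

The most relevant measured step is a 10-fold higher number from compound 1 to compound 3 (1.02 log units; beyond the scatter), a large one, which links ((pyrrolidin-1-yl)carbonyl)methyl to cyclopropyl, the group in the series closest to propyl. The step of a 3.6-fold higher number from compound 2 to compound 3 (0.56 log units; beyond the scatter) is modest and shows that compound 3 also stands apart from the 2-(piperidin-1-yl)ethyl chain of compound 2. The step of a 2.9-fold higher number from compound 1 to compound 2 (0.46 log units; beyond the scatter) is likewise modest. On these data alone, no open-chain group without a hetero atom has been measured yet, so the comparison of propyl with cyclopropyl remains untested.

A large step to a lower number is therefore expected in this assay. The expected change is an 8.4-fold lower number from compound 3 to compound 4 (0.93 log units; beyond the scatter). For compound 4 the estimated value is 260 nM, with an expected range of 100 nM to 700 nM.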

Compound 4, half-maximal inhibitory concentration: 220 nM
For compound 4 the middle estimate is 1.2-fold (0.07 log units) above the measured one; the measured number falls inside the stated range.
By their numbers in this assay, from the lowest: compounds 1 and 4 (each within the scatter of the next); then compound 2; then compound 3.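

In this assay, the open propyl chain on the amide-type nitrogen and the cyclopropyl ring at that place cannot be told apart (a 1.0-fold higher number from compound 1 to compound 4 (0.02 log units; within the scatter)), so among these compounds a ring directly on this nitrogen is not required for the lowest numbers in the series. Among these compounds, compound 4 also gives the first comparison of a plain alkyl chain with the two chains that carry a terminal ring: ethyl in place of (pyrrolidin-1-yl)carbonyl gives a 10-fold lower number from compound 3 to compound 4 (1.00 log units; beyond the scatter), and methyl in place of piperidin-1-yl gives a 2.8-fold lower number from compound 2 to compound 4 (0.44 log units; beyond the scatter), so both compound 2 and compound 3 lie on the weaker side of the unadorned chain, with no compound in the set going against this. Nothing measured here accounts for these differences.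

On these data alone, whether a longer chain such as butyl or hexyl, or a branched group such as isopropyl or tert-butyl, stays level with propyl and cyclopropyl remains open. Also open, as far as these compounds go, is whether the terminal ring or its hetero atom carries the shift, which a chain ending in cyclohexyl, a simple dimethylamine or a carboxylic acid would help to separate.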